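The source may report more compounds than this note shows. Statements on the series, on what has been measured and on what is new or still open speak of the compounds shown alone.

Values in an ADME assay on the whole organism with Oryza sativa as the target, tested at 10 uM; a higher number here means a weaker effect of the compound at the concentration tested, a lower number a stronger effect:

compound 1 `CC(=O)c1ccccc1NC(=O)N[C@H](C)c1ccccc1`: 89%
compound 2 `CC(=O)c1ccc(NC(=O)N[C@H](C)c2ccccc2)cc1`: 84%
compound 3 `C[C@@H](NC(=O)Nc1ccccc1F)c1ccccc1`: 77%

Compound 1 and compound 2 share the same atoms joined differently; the difference between the two cores is not broken down here. Their readings in this assay lie within the scatter of each other. Compound 1 and compound 3 differ in one place, (fluoro in place of acetyl on an aromatic carbon), and this gave a number 12 percentage points lower from compound 1 to compound 3 (beyond the scatter). Compound 2 and compound 3 also fall within the scatter of each other.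

Compound 4 `C[C@@H](NC(=O)Nc1ccc(F)cc1)c1ccccc1` is not yet measured. It differs from compound 2 by fluoro in place of acetyl on an aromatic carbon. The change is of the same kind as that from compound 1 to compound 3, but the place is not identical: in compound 3 the fluoro stands ortho to a large group, in compound 4 para to a large group.

For the measured compounds named here, the step in this assay from compound 2 to compound 4 is expected to be a number 11 percentage points lower from compound 2 to compound 4 (beyond the scatter), because a number 12 percentage points lower from compound 1 to compound 3 (beyond the scatter) was seen for the same kind of change; only one such step exists, so the expectation is loose. Compound 4 is estimated at 73%, between 60% and 86%.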

Compound 4, a percentage reported as activity, at one concentration (the size of the read-out at that concentration, not a potency): 92%
Compound 4: the middle estimate sits 19 percentage points below what was measured, and the stated range ends below it.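

In this assay, for the compounds shown here, fluoro in place of acetyl on an aromatic carbon, para to a large group, gave a number 8 percentage points higher from compound 2 to compound 4 (within the scatter), so this pair shows no step that can be told from the scatter. The same kind of change therefore does not carry over as one fixed step between the two cores: the same change on two cores in this assay, a number 12 percentage points lower (beyond the scatter) from compound 1 to compound 3 and a number 8 percentage points higher (within the scatter) from compound 2 to compound 4, 20 percentage points apart, beyond the scatter of two such steps. Going by these compounds alone, with only one pair on each core, the data show that a step seen on one core cannot simply be transferred to the other, but they do not show what sets the two steps apart, and they give no rule for any further core.

Acetyl and fluoro are the only groups compared at this aromatic carbon, so it remains open how an amine, a nitrile or a carboxylic acid there would read in this assay. From the compounds shown here alone, it also remains open whether a longer chain in place of acetyl would follow the step seen on the core of compound 1, the step seen on the core of compound 2, or neither.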